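Trifluoromethyl on compound 1: a small step expected

This account rests on a few compounds, and the source may have more. Where it says the series, first, only, none or still open, it means among the compounds named here.

In a functional assay on K562 cells (Homo sapiens) for inhibition, read by sulforhodamine B assay, with a stated time of 48 h (on this read-out higher numbers stand for weaker inhibition of growth and lower numbers for stronger inhibition of growth), compound 1 (`CC1(/C=C/c2ccccc2)C=CC(=O)O1`) gives > 1000000 nM, which is a limit of the assay and not a number. Compound 2 (`CC1(/C=C/c2ccccc2C(F)(F)F)C=CC(=O)O1`), with trifluoromethyl in place of hydrogen on a different aromatic carbon, gives 573000 nM. Going by the values given here, the one measured step that bears on the next compound is an at least 1.7-fold lower number from compound 1 to compound 2 (0.24 log units; that floor lies within the scatter). Compound 3 (`CC1(/C=C/c2ccc(C(F)(F)F)cc2)C=CC(=O)O1`) differs from compound 1 by trifluoromethyl in place of hydrogen on an aromatic carbon. Among the compounds with values here, with only that small step as a guide, little change beyond the scatter is expected in this assay, and the estimate means an at least 1.6-fold lower number from compound 1 to compound 3 (0.22 log units; that floor lies within the scatter). For compound 3 the expected value is 600000 nM, within an estimated range of 250000 nM to 1000000 nM.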

Compound 3, concentration for total growth inhibition: 652000 nM
Compound 3: the middle estimate sits 1.1-fold (0.04 log units) below what was measured, within the range that was stated.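

In this assay, trifluoromethyl on this aromatic carbon, para to a group of 9 heavy atoms, also gives a readable number, and the change amounts to an at least 1.5-fold lower number from compound 1 to compound 3 (0.18 log units; that floor lies within the scatter). Compound 1 gives > 1000000 nM, which is a limit and not a number. The true size of the step therefore stays unknown, and only its floor can be stated: the limit of > 1000000 nM in this assay, at which 1 of the 3 values shown sits.

As far as these compounds go, whether an amine, a carboxylic acid or a longer chain on this same aromatic carbon would give a step beyond the scatter remains open. Also open, from the compounds shown here alone, is how a smaller group, such as a single fluorine, would behave here.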